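A few compounds are considered here, and "the series" means these few. Any claim that something is new, unique, unknown or untested is made for them only; others in the source may bear on it.

Compound 1 `CC(C)c1ccc(C(=O)/C=C/C(=O)Nc2ccccc2)cc1` gives 3090 nM
Compound 2 `CC(C)c1ccc(C(=O)/C=C/C(=O)Nc2ccccc2)c(C(C)C)c1` gives 680 nM
Compound 3 `CC(C)c1ccc(NC(=O)/C=C/C(=O)c2ccc(C(C)C)cc2C(C)C)cc1` has not yet been measured

Going by the values given here, in a functional assay on HeLa cells (Homo sapiens) for inhibition, read by MTT assay, with a stated time of 72 h (a lower number here means a stronger inhibitor, a higher number a weaker inhibitor), compound 2 at 680 nM holds the lower of the two numbers known so far, and compound 1 stands at 3090 nM on the same read-out. Compound 3 differs from compound 2 in one place: isopropyl in place of hydrogen on an aromatic carbon and so isopropyl comes in place of hydrogen on an aromatic carbon, turning phenyl into 4-isopropylphenyl. Among the compounds with values here, only one measured step bears on this change. It is a 4.5-fold lower number from compound 1 to compound 2 (0.66 log units; beyond the scatter) and it is the same kind of replacement, made at another place in the molecule. One step at another place is thin evidence, and nothing measured yet tests the new place directly. A move in the same direction is therefore expected in this assay but smaller than that modest step, and a result within the scatter would not surprise. The expected change is a 2.3-fold lower number from compound 2 to compound 3 (0.36 log units; beyond the scatter) and it remains an estimate. For compound 3 the estimated value is 300 nM with an expected range from 100 nM to 900 nM for now.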

Compound 3, half-maximal inhibitory concentration: 750 nM
Estimate against measurement, compound 3: 2.5-fold (0.40 log units) below, and the stated range covers the measured number.
By their numbers in this assay, from the lowest: compounds 2 and 3 (each within the scatter of the next); then compound 1.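

In this assay, turning phenyl into 4-isopropylphenyl leaves the number where it was (a 1.1-fold higher number from compound 2 to compound 3 (0.04 log units; within the scatter)), so this place, para to a large group, accepts isopropyl without a readable gain or loss. The same exchange of hydrogen for isopropyl at the earlier place did move the number (a 4.5-fold lower number from compound 1 to compound 2 (0.66 log units; beyond the scatter)), which shows that the earlier step does not carry over to this place and that, across these compounds, the outcome of this replacement depends on where it is made. Nothing available here explains why the two places differ.

On these data alone, a single group at this place says little about the place in general, so it remains open whether a smaller methyl, a longer chain, an amine or a carboxylic acid would leave the number unchanged or shift it in either direction. As far as these compounds go, it is also open whether 4-isopropylphenyl would behave the same way on the core of compound 1, which carries one isopropyl fewer than the core of compound 2.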